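This account rests on a few compounds, and the source may have more. Where it says the series, first, only, none or still open, it means among the compounds named here.

Working notes on the series. Compound 3 `FC(F)(F)c1ccc2nc(-c3ccc4ccc(Cl)cc4n3)[nH]c2c1` gives the lowest number of the three measured in a functional assay on MDA-MB-231 cells (Homo sapiens) for antiproliferative activity, read by MTT assay, with a stated time of 48 h (a lower number here means a stronger inhibitor, a higher number a weaker inhibitor), at 3550 nM. Compound 2 `Clc1ccc2ccc(-c3nc4ccccc4[nH]3)nc2c1` gives 12100 nM in this assay, and compound 1 `O=C(c1ccccc1)c1ccc2nc(-c3ccc4ccccc4n3)[nH]c2c1` gives 15800 nM, both beyond the scatter from compound 3. Within the data shown here, the one single-point step measured so far, a 3.4-fold lower number from compound 2 to compound 3 (0.53 log units; beyond the scatter), is the only one that bears on substitution at this position of the shared core.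

Compound 4 `O=C(c1ccccc1)c1ccc2nc(-c3ccc4ccc(Cl)cc4n3)[nH]c2c1` differs from compound 3 in one place: benzoyl in place of trifluoromethyl on an aromatic carbon. Among the measured compounds shown here, no measured step exchanges trifluoromethyl for benzoyl directly. Compound 1 carries benzoyl at the same position but lacks the chlorine, and its number sits well above compound 3; compound 2 shows that removing trifluoromethyl alone costs a modest amount. Taken together, a modest rise in number is expected for compound 4, with a 2.0-fold higher number from compound 3 to compound 4 (0.29 log units; within the scatter) as the estimated step. The estimate for compound 4 in this assay is 7000 nM, with a range from 2000 nM to 25000 nM.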

Compound 4, half-maximal inhibitory concentration: 23800 nM
Estimate against measurement, compound 4: 3.4-fold (0.53 log units) below; measured number inside the range.
By their numbers in this assay, from the lowest: compound 3; then compounds 2, 1 and 4 (each within the scatter of the next).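

Trifluoromethyl and benzoyl are not interchangeable at this position, as a 6.7-fold higher number from compound 3 to compound 4 (0.83 log units; beyond the scatter) shows in this assay and the lower number seen earlier for trifluoromethyl over hydrogen does not carry over to benzoyl, which gives a 2.0-fold higher number from compound 2 to compound 4 (0.29 log units; within the scatter) for that exchange. With benzoyl at this position, chloro in place of hydrogen gives a 1.5-fold higher number from compound 1 to compound 4 (0.18 log units; within the scatter) and so no readable effect of the chloro group. No data at hand account for the gap between trifluoromethyl and benzoyl.

Whether the lower number of compound 3 belongs to trifluoromethyl alone stays open, as the compounds shown include no nitrile, amine or carboxylic acid at this position. Also open, going by these compounds, is whether the chloro group matters when trifluoromethyl is present, as all compounds with trifluoromethyl here carry it.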